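The compounds below may be only part of what the source reports. "The series", "measured", "known", "first", "only" and "open" are said of these compounds alone.

Three compounds share one core and differ only in the group carried on the silicon. Compound 1 `CCN(C/C=C/C#CC(C)(C)C)Cc1cccc(OC[Si](C)(C)c2ccc(F)cc2)c1` gives 60 nM in a functional assay on liver (Sus scrofa) for inhibition of squalene monooxygenase (Homo sapiens), using microsomes; a lower number here means a stronger inhibitor, a higher number a weaker inhibitor; compound 2 `CCN(C/C=C/C#CC(C)(C)C)Cc1cccc(OC[Si](C)(C)c2ccc(Cl)cc2)c1` gives 400 nM; compound 3 `CCN(C/C=C/C#CC(C)(C)C)Cc1cccc(OC[Si](C)(C)c2ccccc2C(F)(F)F)c1` gives 70 nM. Compound 1 has the lowest number of the three, although compound 3 sits so close that the two cannot be told apart: the step of a 1.2-fold higher number from compound 1 to compound 3 (0.07 log units; within the scatter) is within the scatter. Only compound 2 is clearly weaker, by a 6.7-fold higher number from compound 1 to compound 2 (0.82 log units; beyond the scatter), and the step of a 5.7-fold lower number from compound 2 to compound 3 (0.76 log units; beyond the scatter) recovers that loss.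

Compound 4 `CCN(C/C=C/C#CC(C)(C)C)Cc1cccc(OC[Si](C)(C)c2ccc(S)cc2)c1` is not yet measured. It differs from compound 1 by sulfanyl in place of fluoro on an aromatic carbon. For the measured compounds named here, the one measured step that bears directly on this is the exchange at the same aromatic carbon from compound 1 to compound 2, which raised the number by a 6.7-fold higher number from compound 1 to compound 2 (0.82 log units; beyond the scatter); there, too, fluoro was replaced by a larger single atom. On that basis a step upward beyond the scatter is expected for compound 4, though smaller than that seen for compound 2 is as likely as larger, so the range is wide. The expected step for compound 4 is a 4.2-fold higher number from compound 1 to compound 4 (0.62 log units; beyond the scatter). Compound 4 is estimated at 250 nM, with a likely range from 80 nM to 800 nM.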

Compound 4, half-maximal inhibitory concentration: 8000 nM
For compound 4 the middle estimate is 32-fold (1.51 log units) below the measured one, and the stated range ends below it.
By their numbers in this assay, from the lowest: compounds 1 and 3 (each within the scatter of the next); then compound 2; then compound 4.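

Of the changes seen so far at this aromatic carbon, sulfanyl in place of fluoro gives by far the largest rise in the number in this assay (a 130-fold higher number from compound 1 to compound 4 (2.12 log units; beyond the scatter)), and compound 4 is just as clearly separated from the other strong inhibitor (a 110-fold higher number from compound 3 to compound 4 (2.06 log units; beyond the scatter)). Fluoro, chloro and sulfanyl each place a single heavy atom here, yet the change from chloro to sulfanyl still has a large effect (a 20-fold higher number from compound 2 to compound 4 (1.30 log units; beyond the scatter)), so across compounds 1, 2 and 4 the count of heavy atoms at this carbon does not set the number, while the identity of the group clearly matters. Nothing measured here accounts for this large loss.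

The compounds shown cannot separate the sulfur atom itself from the hydrogen it carries, a question that a methylthio group at the same carbon could address, while a hydroxyl group or an amine could test whether other groups bearing a hydrogen-bond donor behave like sulfanyl. On these data alone, it also remains open whether sulfanyl would have a similar effect on a ring that carries a trifluoromethyl group, as in compound 3.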